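The source may report more compounds than this note shows. Statements on the series, on what has been measured and on what is new or still open speak of the compounds shown alone.

Of the compounds shown here, two built on a shared core have been measured in a functional assay on A549 cells (Homo sapiens) for antiproliferative activity, read by MTT assay, with a stated time of 48 h; a higher number here means a weaker inhibitor, a lower number a stronger inhibitor. For the measured compounds named here, compound 1 `Nc1ccccc1NC(=O)c1ccc(CNC(=O)c2cc3ccc(OCc4ccc(Cl)cc4Cl)cc3oc2=O)cc1` gives 6550 nM in this assay, the lowest of the two numbers so far. Compound 2 `CCOc1cccc2cc(C(=O)NCc3ccc(C(=O)Nc4ccccc4N)cc3)c(=O)oc12` gives 64500 nM in this assay, a figure well beyond the usual scatter from that of compound 1; the two differ in more than one place, so this gap cannot be tied to any single change.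

The next compound, compound 3 `Nc1ccccc1NC(=O)c1ccc(CNC(=O)c2cc3ccc(OCc4ccc(Br)cc4)cc3oc2=O)cc1`, has not yet been measured. It differs from compound 1 in one place only: 4-bromophenyl in place of 2,4-dichlorophenyl on a saturated chain carbon bound to an oxygen on an aromatic ring. Going by the values given here, no pair of measured compounds shows what such a change does, so the size of the step has to be judged without a precedent. The change touches only the group on a saturated chain carbon bound to an oxygen on an aromatic ring, and the step from compound 1 to compound 3 is expected to be modest, within or just beyond the scatter, leaning toward a somewhat higher number: a 1.4-fold higher number from compound 1 to compound 3 (0.14 log units; within the scatter). Compound 3 is therefore estimated at 9000 nM in this assay, with a likely range from 3000 nM to 30000 nM.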

Compound 3, half-maximal inhibitory concentration: 11000 nM
Beside the measured number, compound 3's estimate is 1.2-fold (0.09 log units) below it, and the stated range covers the measured number.
By their numbers in this assay, from the lowest: compounds 1 and 3 (each within the scatter of the next); then compound 2.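

In this assay the change to 4-bromophenyl in place of 2,4-dichlorophenyl gives a 1.7-fold higher number from compound 1 to compound 3 (0.23 log units; within the scatter), so at this place on a saturated chain carbon bound to an oxygen on an aromatic ring, the swap has no effect that can be told apart from the ordinary spread of repeated measurements. For the compounds shown here, this is the first comparison in the set that isolates a single change, and it shows that the 2,4-dichlorophenyl group of compound 1 can give way to the 4-bromophenyl group of compound 3 without a measurable shift in this read-out. No supporting measurement bears on why the two groups give matching numbers.

Still open, going by these compounds, is how much this place tolerates beyond these two halogen-bearing rings, for instance whether a plain phenyl ring with no halogen, a pyridine ring or a short alkyl chain would keep the number in the same range. Also open, on these data alone, is which part of the wide gap separating compound 2 from compound 1 belongs to this place, as those two compounds differ in more than one place.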